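Bromo for Methyl: What to Expect of Compound 3

The source may hold more compounds than are shown below. What is called first, only, known or untested is meant among the compounds shown, and "the series" means these compounds.

Among the measured compounds shown here, compound 2 `Cc1ccc(/C=C2\C(=O)c3ccccc3OC2c2ccccc2)cc1` stands highest of the two numbers measured so far in a functional assay on WM-115 cells (Homo sapiens) for cytotoxicity, read by MTT assay, with a stated time of 46 h (on this read-out higher numbers stand for weaker inhibition and lower numbers for stronger inhibition), where compound 2 gives 57000 nM. Its nearest neighbour, compound 1 `O=C1/C(=C\c2ccncc2)C(c2ccccc2)Oc2ccccc21`, gives 4600 nM in this assay, and the step of a 12-fold higher number from compound 1 to compound 2 (1.09 log units; beyond the scatter) is large. Compound 3 `O=C1/C(=C\c2ccc(Br)cc2)C(c2ccccc2)Oc2ccccc21` differs from compound 2 by bromo in place of methyl on an aromatic carbon. For the measured compounds named here, no measured step exchanges bromo for methyl; the only step known replaces the whole pyridin-4-yl by 4-methylphenyl, so it bears only loosely on this change. The step of a 1.9-fold lower number from compound 2 to compound 3 (0.28 log units; within the scatter) is therefore expected to stay small. The estimate for compound 3 in this assay is 30000 nM, with a range from 8000 nM to 100000 nM.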

Compound 3, half-maximal inhibitory concentration: 32600 nM
Compound 3: the middle estimate sits 1.1-fold (0.04 log units) below what was measured, within the range that was stated.
By their numbers in this assay, from the lowest: compound 1; then compounds 3 and 2 (each within the scatter of the next).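

In this assay the exchange on the aromatic carbon para to a large group gives a 1.7-fold lower number from compound 2 to compound 3 (0.24 log units; within the scatter) and so leaves the number within the scatter, with bromo and methyl not told apart at this position. The 4-bromophenyl group, like 4-methylphenyl, stands apart from pyridin-4-yl, with a 7.1-fold higher number from compound 1 to compound 3 (0.85 log units; beyond the scatter) beyond the scatter. No evidence bears on the reason for either step. The compounds shown leave open whether an amine or a carboxylic acid at this position would stay with methyl and bromo or fall nearer compound 1.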